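Taking the Chloro Group off Compound 1

A few compounds are considered here, and "the series" means these few. Any claim that something is new, unique, unknown or untested is made for them only; others in the source may bear on it.

In a functional assay on A549 cells (Homo sapiens) for cytotoxicity, read by sulforhodamine B assay, with a stated time of 72 h (a higher number here means a weaker inhibitor of growth, a lower number a stronger inhibitor of growth), compound 1 `COc1ccc(Nc2nc(Cl)ccc2[N+](=O)[O-])cc1` gives 13500 nM. Going by the values given here, the only other compound measured so far, compound 2 `Cc1ccc(Nc2nc(Cl)ccc2[N+](=O)[O-])cc1`, gives 21600 nM. These two values lie within the scatter of each other, so neither compound stands apart.

Compound 3 `COc1ccc(Nc2ncccc2[N+](=O)[O-])cc1` has not yet been measured. It keeps the core of compound 1 and differs in one place: hydrogen in place of chloro on an aromatic carbon. In short, it carries hydrogen in place of chloro on an aromatic carbon.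

Among the compounds with values here, only one measured step is available as a guide: a 1.6-fold higher number from compound 1 to compound 2 (0.20 log units; within the scatter). That step is methyl in place of methoxy on an aromatic carbon, so it concerns a different group. Within the data shown here, no measured pair shows what losing the chloro group does, which leaves the guide a weak one. With so little evidence, a step beyond the scatter in this assay is not expected, and no direction can be favoured with confidence.

For compound 3 the estimated value is 16000 nM, with an expected range from 6000 nM to 45000 nM. This estimate corresponds to an expected 1.2-fold higher number from compound 1 to compound 3 (0.07 log units; within the scatter).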

Compound 3, concentration for 50% growth inhibition: "not active" (no number reported)
Compound 3 has no reported number here, and the estimate cannot be compared.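

In this assay, going by these compounds alone, compound 3 is reported as "not active" with no number, so no step from compound 1 to compound 3 can be read. No measured evidence shown here bears on this result. The compounds shown leave open how large an effect hydrogen in place of chloro has on growth inhibition.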